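Bicyclic Imidazole in Place of Pyrazole on the Amide Arm

This account rests on a few compounds, and the source may have more. Where it says the series, first, only, none or still open, it means among the compounds named here.

compound 1, `C[C@@H]1CN(c2sc(C(F)(F)F)nc2-c2nc3ccccc3[nH]2)CCN1C(=O)Cn1cccn1`: 13 nM
compound 2, `Cc1nc(C)n(CC(=O)N2CCN(c3sc(C(F)(F)F)nc3-c3nc4ccc(C(C)(C)O)c(F)c4[nH]3)C[C@H]2C)n1`: 9.4 nM

In a functional assay on CHO-K1 cells for antagonist activity at C-X-C chemokine receptor type 3 (Homo sapiens), read by FLIPR, with a stated time of 10 min, in the presence of a further agent that is not named here (a lower number here means a stronger inhibitor, a higher number a weaker inhibitor), compound 1 gives 13 nM, and compound 2 gives 9.4 nM. These two numbers lie within the usual scatter of each other, so compound 1 cannot be set apart from compound 2 on this assay. Compound 3 `C[C@@H]1CN(c2sc(C(F)(F)F)nc2-c2nc3ccccc3[nH]2)CCN1C(=O)Cn1cnc2c1CCN(C)C2` has not yet been measured in this assay. It differs from compound 1 in one place: a group of 10 heavy atoms (7 carbon, 3 nitrogen; one five-membered aromatic ring with 2 hetero atoms, one six-membered non-aromatic ring with 1 hetero atom) in place of a group of 5 heavy atoms (3 carbon, 2 nitrogen; one five-membered aromatic ring with 2 hetero atoms), on a saturated chain carbon bound to a carbonyl carbon. For the measured compounds named here, no pair of measured compounds isolates this kind of change, so the expectation rests on the two values alone. Because compound 1 at 13 nM and compound 2 at 9.4 nM agree although compound 2 carries, among other changes, a different group on the saturated chain carbon bound to a carbonyl carbon, little movement is expected from the larger group entering in compound 3. The expected step from compound 1 to compound 3 is a 1.5-fold higher number from compound 1 to compound 3 (0.19 log units; within the scatter), not clearly beyond the scatter. Compound 3 is therefore estimated at 20 nM, within a range from 6 nM to 60 nM.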

Compound 3, half-maximal inhibitory concentration in the C-X-C chemokine receptor type 3 assay: 3.6 nM
The estimate for compound 3 lay 5.6-fold (0.74 log units) above the measured number, outside the stated range (below it).
By their numbers in the C-X-C chemokine receptor type 3 assay, from the lowest: compound 3; then compounds 2 and 1 (each within the scatter of the next).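

In the C-X-C chemokine receptor type 3 assay, the group of 10 heavy atoms, with its one six-membered non-aromatic ring, replaces the 1H-pyrazol-1-yl group on a saturated chain carbon bound to a carbonyl carbon and gives a 3.6-fold lower number from compound 1 to compound 3 (0.56 log units; beyond the scatter); this is the first single-place change shown here, and it marks this position as one where the number can move beyond the scatter. In a physicochemical assay for solubility, in simulated intestinal fluid (a lower number here means a less soluble compound, a higher number a more soluble compound), compound 1 gives 734 ug/mL as a number. In the physicochemical assay the reading for compound 3 of > 920 ug/mL is a limit and not a number: the limit of > 920 ug/mL in the physicochemical assay, at which 1 of the 2 values shown sits. In the physicochemical assay the change gives an at least 1.2-fold higher number from compound 1 to compound 3 (0.09 log units; that floor lies within the scatter), which is only a floor, so the two compounds are not set apart there.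

The compounds shown leave open how a carboxylic acid or a primary amine at this position would read in the C-X-C chemokine receptor type 3 assay. They also leave open whether the group in compound 3 would give a similar step on the core of compound 2.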